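A few compounds are considered here, and "the series" means these few. Any claim that something is new, unique, unknown or untested is made for them only; others in the source may bear on it.

In an assay on CHO cells for displacement of a labelled ligand from melanin-concentrating hormone receptor 1 (Rattus norvegicus), read by scintillation counting, with a stated time of 1 h (a lower number here means a stronger inhibitor, a higher number a weaker inhibitor), compound 2 `Cc1c(C2CC2)nc2ccc(-n3ccc(OCc4ccc(Br)cc4)cc3=O)cn12` gives 9.3 nM, the lowest of the two numbers shown. Compound 3 `CCc1nc2ccc(-n3ccc(OCc4ccccc4)cc3=O)cn2c1C` gives 120 nM in this assay, a difference beyond the usual scatter. Compound 1 `Cc1oc2ccc(NC(=O)COc3ccc(OC(F)(F)F)cc3)cc2c1C` reaches only a limit of the assay in this assay, > 1000 nM. Going by the values given here, no pair of measured compounds differs in a single place, so the path to compound 4 `Cc1c(C2CC2)nc2ccc(-n3ccc(OCc4cccnc4)cc3=O)cn12` rests on compound 2 alone. The change is pyridin-3-yl in place of 4-bromophenyl on a saturated chain carbon bound to an oxygen on an aromatic ring. A moderate step toward a higher number, beyond the scatter, is expected for this change. Compound 4 is therefore estimated at 100 nM in this assay, within 20 nM to 600 nM. The expected step is an 11-fold higher number from compound 2 to compound 4 (1.03 log units; beyond the scatter).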

Compound 4, half-maximal inhibitory concentration: > 1000 nM
Compound 4 ended at the assay's limit (the forecaster's own chance of this, stated with the estimate: 5%); middle value at least 10-fold (1.00 log units) from the limit.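

In this assay, this place on the saturated chain carbon bound to an oxygen on an aromatic ring does not treat all six-membered aromatic rings alike: pyridin-3-yl in place of 4-bromophenyl gives an at least 100-fold higher number from compound 2 to compound 4 (2.03 log units; beyond the scatter). For compound 4, > 1000 nM is a limit of the assay and not a number, so the full size of this step stays unknown: the limit of > 1000 nM in this assay, at which 2 of the 4 values shown sit.

This single change removes the bromine and adds a ring nitrogen together, and the compounds shown cannot separate the two. On these data alone, it also remains open how a 4-chlorophenyl or a pyridin-4-yl group would fare at this place.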